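The compounds below may be only part of what the source reports. "The series", "measured", "known", "first", "only" and "open" are said of these compounds alone.

Going by the values given here, in an ADME assay on MDBK cells (Bos taurus) for cytotoxicity, read by MTT assay, with a stated time of 96 h (a lower number here means that less compound is tolerated, a higher number that more compound is tolerated), compound 3 `CC(=O)c1ccc2c(c1)nc(-c1ccc(C(F)(F)F)cc1)n2C1CCCCC1` gives 52000 nM, the only true number so far. Compound 1 `CC(=O)c1ccc2c(c1)nc(-c1ccccc1)n2C1CCCCC1` reads > 100000 nM, which is a limit of the assay. Compound 2 `CC(=O)c1ccc2c(c1)nc(-c1ccc(Cl)cc1)n2C1CCCCC1` also reads > 100000 nM, again a limit. Compound 4 `COc1ccc(-c2nc3cc(C(C)=O)ccc3n2C2CCCCC2)cc1` keeps the core of compound 3 and changes one group: methoxy in place of trifluoromethyl on an aromatic carbon. Among the compounds with values here, two measured steps bear on this: an at least 1.9-fold lower number from compound 1 to compound 3 (0.28 log units; that floor lies within the scatter) and an at least 1.9-fold lower number from compound 2 to compound 3 (0.28 log units; that floor lies within the scatter). Both remove or add trifluoromethyl at this same place, and both floors lie within the scatter. A small move toward a higher number is therefore expected, and it may not clear the scatter. The expected step is a 1.5-fold higher number from compound 3 to compound 4 (0.19 log units; within the scatter). For compound 4 the estimate is 80000 nM, with an expected range of 35000 nM to 180000 nM.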

Compound 4, half-maximal cytotoxic concentration: > 100000 nM
Compound 4: only a limit was reported (the forecaster's own chance of this, stated with the estimate: 55%); middle value at least 1.2-fold (0.09 log units) from the limit.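

In this assay, methoxy at this place joins hydrogen and chloro at the limit, so among these four groups only trifluoromethyl gives a true number (an at least 1.9-fold higher number from compound 3 to compound 4 (0.28 log units; that floor lies within the scatter)). That step is only a floor and lies within the scatter, so it does not yet separate methoxy from trifluoromethyl. The steps from compound 1 and compound 2 to compound 4 cannot be read, since both ends of each are limits: the limit of > 100000 nM in this assay, at which 3 of the 4 values shown sit. Still open, on these data alone, is how an amine or a carboxylic acid at this place would read, and whether either would give a true number.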